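The source may report more compounds than this note shows. Statements on the series, on what has been measured and on what is new or still open speak of the compounds shown alone.

Three compounds share one core and differ only in a chain on its aromatic ring. Compound 1 `CCCCc1ccc(NC(=O)N[C@@H](C)c2ccccc2)cc1` gives 72% in an ADME assay on the whole organism with Oryza sativa as the target, tested at 1 uM; on this read-out higher numbers stand for a weaker effect at the one concentration tested and lower numbers for a stronger effect; compound 2 `CCCCCc1ccc(NC(=O)N[C@@H](C)c2ccccc2)cc1` gives 98%, and compound 3 `CCCCCCCc1ccc(NC(=O)N[C@@H](C)c2ccccc2)cc1` gives 99%. Compound 3 holds the highest number of the three: its value and that of compound 2 sit within the scatter, while a number 27 percentage points higher from compound 1 to compound 3 (beyond the scatter) lies beyond it. Compound 4 `CCOC(=O)c1ccc(NC(=O)N[C@@H](C)c2ccccc2)cc1` is not yet measured and differs from compound 3 in one place: ethoxycarbonyl in place of heptyl on an aromatic carbon. The measured steps lengthen the chain (a number 26 percentage points higher from compound 1 to compound 2 (beyond the scatter), a number 1 percentage points higher from compound 2 to compound 3 (within the scatter)); none swaps the whole chain for ethoxycarbonyl, so they guide only loosely. Because compound 1 with the shortest chain gives 72% and compound 4 carries no chain, a lower number is expected for compound 4, a number 29 percentage points lower from compound 3 to compound 4 (beyond the scatter). Compound 4 is estimated at 70%, between 45% and 95%.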

Compound 4, a percentage reported as activity, at one concentration (the size of the read-out at that concentration, not a potency): 97%
Compound 4: the middle estimate sits 27 percentage points below what was measured; measured number above the stated range.
By their numbers in this assay, from the lowest: compound 1; then compounds 4, 2 and 3 (each within the scatter of the next).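

In this assay, ethoxycarbonyl on this aromatic carbon gives a result that matches the longer chains, both heptyl (a number 2 percentage points lower from compound 3 to compound 4 (within the scatter)) and pentyl (a number 1 percentage points lower from compound 2 to compound 4 (within the scatter)), while butyl stands apart (a number 25 percentage points higher from compound 1 to compound 4 (beyond the scatter)). A high number at this position therefore does not require a long carbon chain, and compound 1 remains the only one of the four set off from the rest. Nothing available explains this match. Going by these compounds, whether a carboxylic acid, an amine or a chain shorter than butyl on this carbon would keep the high number remains open.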